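Lengthening a chain on a weak acetophenone-type inhibitor

The source may report more compounds than this note shows. Statements on the series, on what has been measured and on what is new or still open speak of the compounds shown alone.

All four compounds share a small aromatic core carrying an acetyl group, a methoxy group and a long saturated chain attached through an oxygen on the ring. They were tested in a functional assay, with a stated time of 30 min; a higher number here means a weaker inhibitor, a lower number a stronger inhibitor. Compound 1, `CCCCCCCCCCCCOc1cc(OC)c(Br)cc1C(C)=O`, gives 29500000 nM in this assay. Compound 2, `CCCCCCCCCCCCCCOc1cc(OC)c(Br)cc1C(C)=O`, differs from compound 1 by ethyl in place of hydrogen on a saturated chain carbon, ten or more bonds along the chain from an oxygen on an aromatic ring, and compound 2 gives 16100000 nM. The step between them is a 1.8-fold lower number from compound 1 to compound 2 (0.26 log units; within the scatter). Compound 3, `CCCCCCCCCCOc1cc(OC)ccc1C(C)=O`, lacks the bromine of compound 1 and carries a shorter chain; the difference between these two cores is not broken down here. In this assay compound 3 gives 40100000 nM. All three numbers are very high, meaning all three compounds are weak inhibitors.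

Compound 4, `CCCCCCCCCCCCOc1cc(OC)ccc1C(C)=O`, is not yet measured. It differs from compound 3 by ethyl in place of hydrogen on a saturated chain carbon, ten or more bonds along the chain from an oxygen on an aromatic ring, which is the same change that was made from compound 1 to compound 2, at the same kind of place. Because the measured step of a 1.8-fold lower number from compound 1 to compound 2 (0.26 log units; within the scatter) stayed within the usual scatter, the same change on compound 3 is expected to give only a small step as well. Compound 4 is therefore expected to give about 25000000 nM, with a likely range from 12000000 nM to 50000000 nM. This estimate means an expected step of a 1.6-fold lower number from compound 3 to compound 4 (0.21 log units; within the scatter), which rests on compound 2 giving 16100000 nM after the same change.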

Compound 4, half-maximal inhibitory concentration: 37400000 nM
Estimate against measurement, compound 4: 1.5-fold (0.17 log units) below; the measured number falls inside the stated range.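

In this assay, the second use of ethyl in place of hydrogen on the chain gives a 1.1-fold lower number from compound 3 to compound 4 (0.03 log units; within the scatter), and the two steps for this change, one on the core with bromine and one on the core without it, agree: the same change on two cores in this assay, a 1.8-fold lower number (0.26 log units; within the scatter) from compound 1 to compound 2 and a 1.1-fold lower number (0.03 log units; within the scatter) from compound 3 to compound 4, 1.7-fold (0.23 log units) apart, within the scatter of two such steps

Hydrogen in place of bromo on an aromatic carbon gives a 1.3-fold higher number from compound 1 to compound 4 (0.10 log units; within the scatter), which also lies within the scatter, so on these four compounds neither the chain change nor the bromine leaves a step that can be told apart from repeat-to-repeat noise. This shows that the chain change behaves alike on these two cores only in the modest sense that it gives no clear step on either, and it does not show that the change has any real effect to carry over, nor that the same would hold on a different core or at another chain length.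

As far as these compounds go, what stays open is whether anything on this shared core can move these very high numbers by more than the scatter. A much shorter chain, a much longer chain, or an amine or a carboxylic acid in place of the chain could each test this, and the compounds shown say nothing about any of them.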